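Cyclopropyl on the amide nitrogen of compound 2

This account rests on a few compounds, and the source may have more. Where it says the series, first, only, none or still open, it means among the compounds named here.

Compound 2 `NC(=O)/C=C/c1ccncc1-c1ccc2ccccc2c1` is the starting point for this step. In a functional assay on MDA-MB-231 cells (Homo sapiens) for inhibition, read by sulforhodamine B assay, with a stated time of 72 h (a higher number here means a weaker inhibitor of growth, a lower number a stronger inhibitor of growth), compound 2 gives > 10000 nM as a limit of the assay and not a number. Compound 1 `COC1CN(C(=O)/C=C/c2ccncc2-c2ccc3ccccc3c2)C1` gives > 10000 nM as a limit of the assay too. The series therefore stands at the limit of > 10000 nM in this assay, at which 2 of the 2 values shown sit, and holds no number yet.

Compound 3 `O=C(/C=C/c1ccncc1-c1ccc2ccccc2c1)NC1CC1` departs from compound 2 by one change, cyclopropyl in place of hydrogen on an amide-type nitrogen with cyclopropyl in place of hydrogen on an amide-type nitrogen. Within the data shown here, the only measured step is a step that the two limits leave unreadable from compound 1 to compound 2 and it offers no size to carry over to this change. Among the measured compounds shown here, no measured step therefore points to a direction or a size in this assay for this change, and no shift beyond the scatter is expected. The expectation rests on compound 2 with > 10000 nM as its limit. A further limit is the most likely report for compound 3. The expected step is a step that the limit leaves unreadable from compound 2 to compound 3 as an estimate only. For compound 3 the estimated value is 12000 nM with an expected range from 4000 nM to 30000 nM in this read-out.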

Compound 3, concentration for 50% growth inhibition: 8420 nM
The estimate for compound 3 lay 1.4-fold (0.15 log units) above the measured number, and the stated range covers the measured number.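

On the amide nitrogen, cyclopropyl gives the only number so far in this assay, while the other values shown are limits of the assay and not numbers: the limit of > 10000 nM in this assay, at which 2 of the 3 values shown sit.

Cyclopropyl in place of hydrogen on this amide-type nitrogen gives an at least 1.1-fold lower number from compound 2 to compound 3 (0.07 log units; that floor lies within the scatter), and cyclopropylamino in place of 3-methoxyazetidin-1-yl on the carbonyl carbon gives an at least 1.1-fold lower number from compound 1 to compound 3 (0.07 log units; that floor lies within the scatter). Both steps are floors set by a limit, so this position now has a readable value, but neither step by itself shows a change beyond the scatter.

Going by these compounds, the true size of both steps stays open, since the compounds at the limit hold no number to set against compound 3. Also open, on these data alone, is whether a cyclobutyl ring, a longer chain such as n-butyl, or an amine-bearing chain such as 2-(dimethylamino)ethyl on the same nitrogen would move the number further than cyclopropyl does, or return it to the limit.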